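The source may hold more compounds than are shown below. What is called first, only, known or untested is meant among the compounds shown, and "the series" means these compounds.

Measured so far in a functional assay on the whole organism with Mus musculus as the target (a lower number here means that less compound is needed, a higher number that more compound is needed for the effect), are two compounds:
- compound 1 `CNC(=O)[C@H](C)NCc1ccc(OCc2ccccc2)cc1` at 8.4 mg/kg
- compound 2 `CNC(=O)[C@H](CCSC)NCc1ccc(OCc2ccccc2)cc1` at 239 mg/kg

Compound 1 holds the lower of the two numbers, so less of it is needed for the effect. Compound 3 `CC[C@@H](NCc1ccc(OCc2ccccc2)cc1)C(N)=O` has the same atoms as compound 1, joined differently 1-carbamoylpropyl in place of 1-(methylcarbamoyl)ethyl on an amine nitrogen in one part of the molecule: 1-carbamoylpropyl in place of 1-(methylcarbamoyl)ethyl on an amine nitrogen. Within the data shown here, only one measured step offers any guide, and it is a different change: a 28-fold higher number from compound 1 to compound 2 (1.45 log units; beyond the scatter) came with (methylsulfanyl)methyl in place of hydrogen on a saturated chain carbon. Among the measured compounds shown here, with that single large step as the only evidence, a small rise in the number is expected in this assay, possibly none beyond the scatter. The expected change is a 1.7-fold higher number from compound 1 to compound 3 (0.22 log units; within the scatter) by this estimate. Compound 3 is estimated at 14 mg/kg with an expected range of 6 mg/kg to 45 mg/kg for its measured value.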

Compound 3, dose for half-maximal effect: 55 mg/kg
The estimate for compound 3 lay 3.9-fold (0.59 log units) below the measured number, and the stated range ends below it.
By their numbers in this assay, from the lowest: compound 1; then compound 3; then compound 2.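

Replacing 1-(methylcarbamoyl)ethyl with 1-carbamoylpropyl on the amine nitrogen keeps the same atoms, yet in this assay it gives a 6.5-fold higher number from compound 1 to compound 3 (0.82 log units; beyond the scatter). This position therefore responds to how those atoms are arranged, not only to which atoms are present, and more compound is needed for the effect after the rearrangement. No further measurement bears on why the number rose.

The change removes the methyl on the amide and lengthens the side chain at once, so the compounds shown cannot say which of the two matters more. On these data alone, a 1-carbamoylethyl or a 1-(methylcarbamoyl)propyl group on the same amine nitrogen would separate them, and whether a carboxylic acid could stand in place of the amide also remains open.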